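A few compounds are considered here, and "the series" means these few. Any claim that something is new, unique, unknown or untested is made for them only; others in the source may bear on it.

Measured so far:
Compound 1 `O=S(=O)(Nc1nccs1)c1ccc(Nc2nncc3ccccc23)cc1` gives 39 nM
Compound 2 `Fc1ccc(Nc2nncc3ccccc23)cc1` gives 8.8 nM

In a functional assay on NCI-H460 cells (Homo sapiens) for antiproliferative activity, read by sulforhodamine B assay, with a stated time of 72 h (a higher number here means a weaker inhibitor, a lower number a stronger inhibitor), compound 2 at 8.8 nM holds the lower of the two numbers, and its gap to compound 1 lies beyond the scatter. Compound 3 `NS(=O)(=O)c1ccc(Nc2nncc3ccccc23)cc1` carries sulfamoyl in place of fluoro on an aromatic carbon, para to a large group (sulfamoyl in place of fluoro on an aromatic carbon). Among the compounds with values here, no measured step covers this change, so the guide is thin. Compound 1, at 39 nM here, reads higher than compound 2, so a modest step toward a higher number is expected in this assay and it may lie just beyond the scatter. The expected change is a 3.4-fold higher number from compound 2 to compound 3 (0.53 log units; beyond the scatter) by this estimate. Compound 3 is estimated at 30 nM (range 10 nM to 100 nM).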

Compound 3, half-maximal inhibitory concentration: 17 nM
Estimate against measurement, compound 3: 1.8-fold (0.25 log units) above, within the range that was stated.
By their numbers in this assay, from the lowest: compounds 2 and 3 (each within the scatter of the next); then compound 1.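

Putting sulfamoyl in place of fluoro on this aromatic carbon gives a 1.9-fold higher number from compound 2 to compound 3 (0.29 log units; within the scatter) in this assay and so shows that this position takes the larger group without a change beyond the scatter. Hydrogen in place of 1,3-thiazol-2-yl on the sulfonamide nitrogen gives a 2.3-fold lower number from compound 1 to compound 3 (0.36 log units; beyond the scatter) and so shows that the group on that nitrogen does move the number. Nothing measured here accounts for either step. As far as these compounds go, what remains open is whether an amine or a carboxylic acid at this position would stay as close to compound 2, and whether a methyl group on the sulfonamide nitrogen would read nearer compound 3 or compound 1.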